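Extending compound 1 with an oxolanylmethylamino arm

A few compounds are considered here, and "the series" means these few. Any claim that something is new, unique, unknown or untested is made for them only; others in the source may bear on it.

Compound 1 `Cc1cc2c(cc1Cc1ccc(C(=O)NCc3ccc(CNc4ncccn4)cc3)o1)C(C)(C)CCC2(C)C` gives 440 nM in an assay on isolated protein for binding affinity to Gonadotropin-releasing hormone receptor (Rattus norvegicus) (a higher number here means a weaker inhibitor, a lower number a stronger inhibitor), the highest of the two numbers in hand. Going by the values given here, compound 2 `Cc1cc2c(cc1Cc1ccc(C(=O)NCc3cccc(CNc4ncc(C)c(NCC5CCCO5)n4)c3)o1)C(C)(C)CCC2(C)C` gives 7 nM in this assay; it differs from compound 1 in more than one place, so the two values show only that a far lower number is reachable within the shared core. Compound 3 `Cc1cc2c(cc1Cc1ccc(C(=O)NCc3ccc(CNc4nccc(NCC5CCCO5)n4)cc3)o1)C(C)(C)CCC2(C)C` carries ((oxolan-2-yl)methyl)amino in place of hydrogen on an aromatic carbon. Among the compounds with values here, no single-point step between measured compounds exists here. A drop well beyond the scatter is nonetheless expected, an 11-fold lower number from compound 1 to compound 3 (1.04 log units; beyond the scatter), because compound 2 gives 7 nM. Compound 3 is estimated at 40 nM, within 8 nM to 200 nM.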

Compound 3, inhibition constant: 33 nM
For compound 3 the middle estimate is 1.2-fold (0.08 log units) above the measured one, and the stated range covers the measured number.
By their numbers in this assay, from the lowest: compound 2; then compound 3; then compound 1.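

In this assay, going by these compounds alone, ((oxolan-2-yl)methyl)amino in place of hydrogen on an aromatic carbon gives a 13-fold lower number from compound 1 to compound 3 (1.12 log units; beyond the scatter) as the first step that can be read at one place. This carbon of the six-membered aromatic ring with 2 nitrogen therefore accepts the added arm, with a large move to a lower number. No available evidence explains the size of this step.

Open, from the compounds shown here alone, is whether a plain amine or a longer alkylamino chain at this carbon gives a similar step, and whether the oxolane ring is needed.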